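The compounds below may be only part of what the source reports. "The series", "measured", "known", "first", "only" and "open" are said of these compounds alone.

Of the compounds shown here, two have been measured so far in an ADME assay on Vero cells (Chlorocebus sabaeus) for cytotoxicity, read by crystal violet staining, with a stated time of 72 h; a higher number here means that more compound is tolerated, a lower number that less compound is tolerated. There, compound 1 (`COc1cc(-c2ccc(C(=O)NNC(=S)Nc3ccc(Cl)cc3)c(C)n2)cc(OC)c1OC`) gives 523000 nM and compound 2 (`COc1ccc(NC(=S)NNC(=O)c2ccc(-c3ccc(OC)c(OC)c3)nc2C)cc1`) gives 632000 nM. These two values lie within the usual scatter of each other, so compound 2 cannot be ranked against compound 1. Within the data shown here, the two compounds also differ in more than one place, so they offer no measured step for a single change.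

Compound 3 (`COc1ccc(NC(=S)NNC(=O)c2ccc(-c3cc(OC)c(OC)c(OC)c3)nc2C)cc1`) departs from compound 2 in one place: methoxy in place of hydrogen on an aromatic carbon. The change is methoxy in place of hydrogen on an aromatic carbon, ortho to a methoxy group and meta to a large group. Compound 1 also carries this additional methoxy and gives 523000 nM, so no shift beyond the scatter is expected in this assay. The estimated change is a 1.1-fold lower number from compound 2 to compound 3 (0.05 log units; within the scatter), which would leave the two compounds within the scatter of each other. For compound 3 the expected value is 560000 nM, with an estimated range of 260000 nM to 1100000 nM.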

Compound 3, half-maximal cytotoxic concentration: 506000 nM
Compound 3: middle estimate off by 1.1-fold (0.04 log units), on the high side; the range from low to high includes it.
By their numbers in this assay, from the lowest: compounds 3, 1 and 2 (each within the scatter of the next).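

In this assay, among these compounds, methoxy in place of hydrogen on an aromatic carbon, ortho to a methoxy group and meta to a large group, gives a 1.2-fold lower number from compound 2 to compound 3 (0.10 log units; within the scatter) and so provides the first single-place step at this position, one that shows no shift beyond the scatter. A second single-place step, methoxy in place of chloro on an aromatic carbon, gives a 1.0-fold lower number from compound 1 to compound 3 (0.01 log units; within the scatter) and likewise shows no shift beyond the scatter, so neither of the two changes separates its pair of compounds in this assay. No measured evidence is available to account for either result.

The compounds shown leave open whether a group of a different kind on the same aromatic carbon, such as an amine or a carboxylic acid, would also stay within the scatter of compound 2. They also leave open whether replacing the methoxy of compound 3 that stands in place of chloro with a hydroxyl or a longer chain such as ethoxy would move the number beyond the scatter.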